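Bromo to Iodo on a Six-Membered Aromatic Ring

A few compounds are considered here, and "the series" means these few. Any claim that something is new, unique, unknown or untested is made for them only; others in the source may bear on it.

Of the compounds shown here, two built on the same core have been measured. Compound 1 `O=C1C(Nc2ccccc2F)=CC(=O)c2c1nc1n2[C@H]2OC[C@@H](O)[C@H]2OC1` gives 9820 nM in a functional assay on HeLa cells (Homo sapiens) for inhibition, read by sulforhodamine B assay; a higher number here means a weaker inhibitor, a lower number a stronger inhibitor. Compound 2 `O=C1C=C(Nc2ccc(Br)cc2)C(=O)c2c1nc1n2[C@H]2OC[C@@H](O)[C@H]2OC1` gives 3830 nM in this assay. Compound 2 therefore holds the lower of the two numbers, and the gap to compound 1, which sits higher, lies beyond the usual scatter.

Compound 3 `O=C1C=C(Nc2ccc(I)cc2)C(=O)c2c1nc1n2[C@H]2OC[C@@H](O)[C@H]2OC1` has not been measured yet. It differs from compound 2 in a single place: iodo in place of bromo on an aromatic carbon. Going by the values given here, no pair of measured compounds differs only in such a halogen swap, so the size of this step has no precedent among them. A change of one halogen for the next heavier one is expected to move the number only a little: the step from compound 2 to compound 3 is expected to be a 1.2-fold lower number from compound 2 to compound 3 (0.08 log units; within the scatter), no larger than the scatter in either direction. Compound 3 is accordingly estimated at 3200 nM in this assay, most likely between 1300 nM and 8000 nM.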

Compound 3, half-maximal inhibitory concentration: 4070 nM
Estimate against measurement, compound 3: 1.3-fold (0.10 log units) below, within the range that was stated.
By their numbers in this assay, from the lowest: compounds 2 and 3 (each within the scatter of the next); then compound 1.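

In this assay, the swap of bromo for iodo on the aromatic carbon para to a large group gives a 1.1-fold higher number from compound 2 to compound 3 (0.03 log units; within the scatter), the first step measured at this place on the shared core. Since this step lies within the scatter, the assay does not separate the 4-bromophenyl and 4-iodophenyl compounds, and a heavier halogen at this place leaves the reading indistinguishable from that of compound 2. Nothing available here accounts for this result.

As far as these compounds go, it remains open whether a lighter halogen such as chloro, or a group of another kind such as an amine, a methoxy group or a carboxylic acid, would read the same at this place. From the compounds shown here alone, it is also open whether the same halogen swap would stay within the scatter elsewhere on the ring.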